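From a 3-Chlorobenzyl to a 4-Chlorobenzyl Amine

This account rests on a few compounds, and the source may have more. Where it says the series, first, only, none or still open, it means among the compounds named here.

Three sulfonamides built on a shared core have been tested in a toxicity assay on MCF-10A cells (Homo sapiens) for inhibition, read by MTT assay, with a stated time of 72 h; on this read-out higher numbers stand for weaker inhibition of growth and lower numbers for stronger inhibition of growth. Compound 1 `CN(CCCNS(=O)(=O)c1cc(C(F)(F)F)cc(C(F)(F)F)c1)Cc1ccccc1` gives 26000 nM. Compound 2 `O=S(=O)(NCCCNCc1ccc(-c2ccccc2)cc1)c1cc(C(F)(F)F)cc(C(F)(F)F)c1` gives 2800 nM, and compound 3 `O=S(=O)(NCCCNCc1cccc(Cl)c1)c1cc(C(F)(F)F)cc(C(F)(F)F)c1` gives 7000 nM. Among these three numbers compound 3 stands second highest: compound 2 sits lower and compound 1 sits higher, both gaps beyond the scatter. Going by the values given here, the only single-point step measured so far, a 3.7-fold lower number from compound 1 to compound 3 (0.57 log units; beyond the scatter), exchanged a benzyl(methyl)amino group for a (3-chlorobenzyl)amino group.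

Compound 4 `O=S(=O)(NCCCNCc1ccc(Cl)cc1)c1cc(C(F)(F)F)cc(C(F)(F)F)c1` has not yet been measured. Its difference from compound 3 is 4-chlorophenyl in place of 3-chlorophenyl on a saturated chain carbon bound to an amine nitrogen; the same atoms are present, joined differently, so the change reads as 3-chlorobenzyl to 4-chlorobenzyl. Among the compounds with values here, no measured step compares two placements of the same substituent, so nothing tested bears directly on this change. Compound 2, which also carries a substituted benzyl ring, gives a lower number than compound 3, but that pair differs in more than one place and was not measured as a step.

Within the data shown here, with no direct precedent, a small change is expected. The step of a 1.4-fold lower number from compound 3 to compound 4 (0.15 log units; within the scatter) is estimated to stay within the scatter. Compound 4 is therefore expected to give about 5000 nM, with a range from 2000 nM to 15000 nM.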

Compound 4, concentration for 50% growth inhibition: 2300 nM
For compound 4 the middle estimate is 2.2-fold (0.34 log units) above the measured one; the measured number falls inside the stated range.
By their numbers in this assay, from the lowest: compounds 4 and 2 (each within the scatter of the next); then compound 3; then compound 1.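

In this assay, going by these compounds alone, the same atoms joined differently give a 3.0-fold lower number from compound 3 to compound 4 (0.48 log units; beyond the scatter), so on this benzyl ring the placement of one chloro counts by itself, which no earlier pair could show. With the chloro held at its new place, a 1.2-fold lower number from compound 2 to compound 4 (0.09 log units; within the scatter), so chloro and phenyl on that aromatic carbon cannot be told apart here, even though one is far larger than the other in heavy atoms alone. The step of an 11-fold lower number from compound 1 to compound 4 (1.05 log units; beyond the scatter) is the widest gap among the compounds shown, and nothing measured here accounts for why placement matters.

That widest step changes the methyl on the amine nitrogen and the chloro together, so how much of the gap belongs to each stays unsplit. On these data alone, whether a methoxy or a nitrile in place of the chloro would behave like chloro and phenyl, and what a longer chain between the sulfonamide nitrogen and the amine nitrogen would do, also remain open.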